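A few compounds are considered here, and "the series" means these few. Any claim that something is new, unique, unknown or untested is made for them only; others in the source may bear on it.

Measured compounds and their values:

- compound 1, `N#Cc1cc(-c2nc(C(c3ccc(F)cc3)c3ccc(F)cc3)sc2CC(=O)O)ccc1F`: 520 nM
- compound 2, `Cc1nc(-c2ccc(Cl)cc2)c(CC(=O)O)s1`: 41000 nM
- compound 3, `O=C(O)Cc1sc(C(c2ccc(F)cc2)c2ccc(F)cc2)nc1-c1ccnc(N2CCCC2)c1`: a limit, > 100000 nM

In an in vitro functional assay on HEK285-7 cells for antagonist activity at prostaglandin D2 receptor 2 (Homo sapiens), read by BRET and beta-arrestin recruitment (on this read-out higher numbers stand for weaker inhibition and lower numbers for stronger inhibition), compound 1 gives 520 nM, the lower of the two numbers obtained, while compound 2 gives 41000 nM, a far higher number. For compound 3 the measurement stops at a limit of the assay and returns no number, > 100000 nM (the limit of > 100000 nM in this assay, at which 1 of the 3 values shown sits).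

Compound 4, `O=C(O)Cc1sc(C(c2ccc(F)cc2)c2ccc(F)cc2)nc1-c1ccoc1`, is not yet measured. It differs from compound 1 in one place: furan-3-yl in place of 3-cyano-4-fluorophenyl on an aromatic carbon.

Within the data shown here, only one measured step replaces the same 3-cyano-4-fluorophenyl group of compound 1, and it was large: an at least 190-fold higher number from compound 1 to compound 3 (2.28 log units; beyond the scatter). Among the measured compounds shown here, that entering group was 2-(pyrrolidin-1-yl)pyridin-4-yl; furan-3-yl is a five-membered aromatic ring with 1 hetero atom, so the change is not the same, but the sole precedent points toward a weaker inhibitor. In this assay the step is expected to be a 12-fold higher number from compound 1 to compound 4 (1.06 log units; beyond the scatter), smaller than the measured step to compound 3. Compound 4 is thus estimated to give about 6000 nM, with a likely range from 1200 nM to 40000 nM.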

Compound 4, half-maximal inhibitory concentration: 130 nM
Estimate against measurement, compound 4: 46-fold (1.66 log units) above; measured number outside the range, below it.
By their numbers in this assay, from the lowest: compound 4; then compound 1; then compound 2. At a limit, above all of these: compound 3.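

In this assay, this position does not depend on the 3-cyano-4-fluorophenyl group: furan-3-yl, a five-membered aromatic ring with 5 heavy atoms in place of 9, gives a 4.0-fold lower number from compound 1 to compound 4 (0.60 log units; beyond the scatter). The earlier compounds shown here showed only a loss of inhibition on changing this group, whereas the two changes now span a wide range, with an at least 760-fold lower number from compound 3 to compound 4 (2.88 log units; beyond the scatter), so the group entering here can move the number strongly in either direction. The entry for compound 3 is a limit and not a number: the limit of > 100000 nM in this assay, at which 1 of the 4 values shown sits.

Going by these compounds, what remains open is which difference from compound 1 matters most: the ring size, the ring oxygen or the absence of the nitrile and fluorine. On these data alone, it is also open whether a thiophen-3-yl ring or an unsubstituted phenyl ring would behave like furan-3-yl at this position.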